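The source may hold more compounds than are shown below. What is called first, only, known or untested is meant among the compounds shown, and "the series" means these compounds.

Working notes on the series.

In a functional assay on MCF7 cells (Homo sapiens) for antiproliferative activity, read by WST assay, with a stated time of 72 h (a lower number here means a stronger inhibitor, a higher number a weaker inhibitor), compound 1 `CCCCCCCCCCCCCC/N=c1\nc(N)c2ncn(Cc3ccccc3)c2c(N)n1` gives 4100 nM. Compound 2 `CCCCCCCC/N=c1\nc(N)c2ncn(Cc3ccccc3)c2c(N)n1` gives 4550 nM in this assay. The two share the same core and differ only in the chain on the double-bonded nitrogen: hexyl in place of hydrogen on a saturated chain carbon, eight bonds along the chain from a double-bonded nitrogen. That change produced a 1.1-fold lower number from compound 2 to compound 1 (0.05 log units; within the scatter), so lengthening the chain at this place left the potency unchanged as far as these two compounds show.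

Compound 3 `CC/N=c1\nc(N)c2nc[nH]c2c(N)n1` carries a shorter chain and a different core, and in this assay compound 3 reaches only the limit of > 100000 nM, which is a limit of the assay and not a number. How the core of compound 3 differs from the core of compound 2 is not broken down here.

Compound 4 `CCCCCCCC/N=c1\nc(N)c2nc[nH]c2c(N)n1` is the compound not yet measured. It stands to compound 3 as compound 1 stands to compound 2: hexyl in place of hydrogen on a saturated chain carbon, two bonds along the chain from a double-bonded nitrogen. The place is not the same word for word: in compound 2 to compound 1 the hexyl enters eight bonds along the chain from the double-bonded nitrogen, in compound 3 to compound 4 it enters two bonds along the chain from the double-bonded nitrogen, so this is the same kind of change rather than the same change. Among the compounds with values here, the only measured precedent is the step from compound 2 to compound 1, which lay within the scatter, and compound 3 itself sits at the limit of > 100000 nM in this assay, at which 1 of the 3 values shown sits. On that basis the step from compound 3 to compound 4 in this assay is expected to be an at least 1.2-fold lower number from compound 3 to compound 4 (0.09 log units; that floor lies within the scatter), with little confidence that a number rather than a limit will be reported. Compound 4 is estimated at 80000 nM in this assay, between 20000 nM and 300000 nM.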

Compound 4, half-maximal inhibitory concentration: "not active" (no number reported)
The entry for compound 4 holds no number; the estimate stays without a comparison.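

In this assay, within the data shown here, compound 4 is reported as "not active" with no number, so no step from compound 3 to compound 4 can be read. Compound 3 stands at a limit and not a number: the limit of > 100000 nM in this assay, at which 1 of the 4 values shown sits.

The compounds shown leave open whether the chain on the double-bonded nitrogen has any bearing on activity on the core shared by compound 3 and compound 4.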